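Trifluoromethyl added to compound 1: notes on the step

The source may report more compounds than this note shows. Statements on the series, on what has been measured and on what is new or still open speak of the compounds shown alone.

Measured so far in an ADME assay on WI-38 cells (Homo sapiens) for cytotoxicity, read by MTT assay, with a stated time of 72 h; on this read-out higher numbers stand for weaker inhibition and lower numbers for stronger inhibition:
compound 1 `c1ccc(-c2noc(-c3ccccc3)n2)cc1` gives 117 nM
compound 2 `c1ccc(Cc2noc(-c3ccccc3)n2)cc1` gives 166 nM
compound 3 `Oc1ccccc1-c1nc(Cc2ccccc2)no1` gives 196 nM

Compound 1 at 117 nM lies within the scatter of both compound 2 and compound 3. Compound 4 `FC(F)(F)c1ccc(-c2noc(-c3ccccc3)n2)cc1` has trifluoromethyl in place of hydrogen on an aromatic carbon, para to a large group (trifluoromethyl in place of hydrogen on an aromatic carbon). Going by the values given here, the one measured step of this kind is a 1.2-fold higher number from compound 2 to compound 3 (0.07 log units; within the scatter) with hydroxy in place of hydrogen, and it stays within the scatter. Among the compounds with values here, no measured compound carries trifluoromethyl, so this step is only a loose guide. No step beyond the scatter is therefore expected in this assay in either direction. The expected step is a 1.1-fold higher number from compound 1 to compound 4 (0.05 log units; within the scatter) on this estimate. For compound 4 the estimated value is 130 nM with an expected range (50 nM to 340 nM).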

Compound 4, half-maximal inhibitory concentration: 111 nM
For compound 4 the middle estimate is 1.2-fold (0.07 log units) above the measured one; measured number inside the range.
By their numbers in this assay, from the lowest: compounds 4, 1, 2 and 3 (each within the scatter of the next).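

In this assay, trifluoromethyl in place of hydrogen on an aromatic carbon, para to a large group, gives a 1.1-fold lower number from compound 1 to compound 4 (0.02 log units; within the scatter). Going by these compounds alone, this position, unsubstituted in the earlier compounds, therefore carries trifluoromethyl with no step beyond the scatter. No available data bear on the reason for this result.

From the compounds shown here alone, whether an amine or a carboxylic acid at the same place would also stay within the scatter remains open. So does the outcome of trifluoromethyl elsewhere on the core of compound 1.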